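Second phosphate on the glycerol-like chain of compound 1

The compounds below may be only part of what the source reports. "The series", "measured", "known", "first", "only" and "open" are said of these compounds alone.

Notes on a small series tested in a functional assay on Vero cells (Chlorocebus sabaeus); on this read-out higher numbers stand for weaker inhibition and lower numbers for stronger inhibition. Within the data shown here, compound 1 `Nc1nc(O)c2ncn(COC(CO)COP(=O)(O)O)c2n1` gives 700 uM in this assay and stands highest of the two numbers measured so far. Compound 2 `Nc1nc2c(ncn2COC2COP(=O)(O)OC2)c(=O)[nH]1`, the ring-closed relative, gives 40 uM in this assay, a lower number that lies beyond the scatter of compound 1. Among the measured compounds shown here, no step between two measured compounds that differ in a single place is available, so the next change has no direct precedent.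

Compound 3 `Nc1nc(O)c2ncn(COC(COP(=O)(O)O)COP(=O)(O)O)c2n1` differs from compound 1 by a group of 4 heavy atoms (3 oxygen, 1 phosphorus; no ring) in place of a hydrogen atom, on an oxygen on a saturated carbon. The effect of this change cannot be read from any measured pair; the only other point, compound 2, alters the chain in a different way.

For the step from compound 1 to compound 3, a change of about a 1.6-fold lower number from compound 1 to compound 3 (0.19 log units; within the scatter) is expected, towards a lower number but not clearly beyond the scatter. Compound 3 is estimated at 450 uM in this assay, with a range from 120 uM to 1800 uM.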

Compound 3, concentration for 50% inhibition: 800 uM
The estimate for compound 3 lay 1.8-fold (0.25 log units) below the measured number; measured number inside the range.
By their numbers in this assay, from the lowest: compound 2; then compounds 1 and 3 (each within the scatter of the next).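

In this assay a second phosphate, a group of 4 heavy atoms (3 oxygen, 1 phosphorus; no ring) in place of a hydrogen atom on an oxygen on a saturated carbon, gives a 1.1-fold higher number from compound 1 to compound 3 (0.06 log units; within the scatter) and so stays within the scatter. Among these compounds, this is the first step that changes a single place, and it shows that on this read-out the free hydroxyl and the phosphate at this position cannot be told apart, something the earlier compounds could not show on their own. Nothing measured here bears on why this step is so small.

Still open, from the compounds shown here alone, is whether other groups on the same oxygen, such as a methyl ether, an acetyl ester or a carboxylic acid on a short chain, would also stay within the scatter of compound 1, or whether an amine in place of that oxygen would do the same. Among the compounds shown here, also open is which feature of the ring-closed compound 2, at 40 uM, goes with its value, since no single-place step links it to the open-chain compounds.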